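A few compounds are considered here, and "the series" means these few. Any claim that something is new, unique, unknown or untested is made for them only; others in the source may bear on it.

Measured in an ADME assay on TZM cells (Homo sapiens) for cytotoxicity, read by XTT assay, with a stated time of 4 days; on this read-out lower numbers stand for higher toxicity in this test and higher numbers for lower toxicity in this test:
Compound 1 `Cc1cc(Br)cc(C)c1Oc1ccc([N+](=O)[O-])c(Nc2ccc(C#N)cc2)n1`: > 45600 nM, a limit
Compound 2 `Cc1cc(/C=C/C#N)cc(C)c1Oc1ccc([N+](=O)[O-])c(Nc2ccc(C#N)cc2)c1`: > 48700 nM, a limit
Compound 3 `Cc1cc(/C=C/C#N)cc(C)c1Oc1ccc(N)c(Nc2ccc(C#N)cc2)c1`: 25000 nM

Among these three, only compound 3 has a true number, 25000 nM. The other two entries are limits. Compound 4 `Cc1cc(/C=C/C#N)cc(C)c1Oc1cc(Nc2ccc(C#N)cc2)c(N)cc1[N+](=O)[O-]` differs from compound 3 in one place: nitro in place of hydrogen on an aromatic carbon. In words, this is nitro in place of hydrogen on an aromatic carbon.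

Within the data shown here, only one measured step involves a nitro group: an at least 1.9-fold lower number from compound 2 to compound 3 (0.28 log units; that floor lies within the scatter). That step exchanges nitro for amino rather than adding nitro in place of hydrogen, so it bears on this change only loosely. Its floor also lies within the scatter. In this assay, therefore, no step beyond the scatter is expected, and a result reported only as a limit remains possible. The expected step is a 1.1-fold higher number from compound 3 to compound 4 (0.05 log units; within the scatter). Compound 4 is estimated at 28000 nM, with an expected range of 11000 nM to 50000 nM.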

Compound 4, half-maximal cytotoxic concentration: > 47000 nM
Compound 4: no number, only a limit (the forecaster's own chance of this, stated with the estimate: 35%); at least 1.6-fold (0.22 log units) between middle value and limit.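

In this assay, nitro in place of hydrogen on the aromatic carbon para to a (4-cyanophenyl)amino group and meta to an amino group gives an at least 1.8-fold higher number from compound 3 to compound 4 (0.27 log units; that floor lies within the scatter). Compound 4 is reported only as a limit, like compound 1 and compound 2 in this set: the limit of > 47000 nM in this assay, at which 1 of the 4 values shown sits. Among these compounds, this is the first direct view of nitro added in place of hydrogen with the amino group kept, and nothing in it points to a lower number at this position, although the floor of the step stays within the scatter.

From the compounds shown here alone, the true size of this step remains open, with no number for compound 4. Also open, going by these compounds, is what a chlorine atom, a methoxy group or a carboxylic acid would give on the same aromatic carbon.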